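Swapping a Dimethylimidazolyl Sulfonamide for a Dimethylpyrazolyl One

This account rests on a few compounds, and the source may have more. Where it says the series, first, only, none or still open, it means among the compounds named here.

The measured compounds, with their results in an assay on isolated protein for inhibition of phosphoenolpyruvate carboxykinase, cytosolic [GTP] (Homo sapiens); on this read-out higher numbers stand for weaker inhibition and lower numbers for stronger inhibition:
compound 1 `Cc1nc(S(=O)(=O)Nc2ccc(Cc3nc4c([nH]3)c(=O)n(Cc3ccccc3F)c(=O)n4CC3CC3)cc2)cn1C` gives 340 nM;
compound 2 `O=c1c2[nH]c(Cc3ccc(NS(=O)(=O)c4cccnc4)cc3)nc2n(CC2CC2)c(=O)n1Cc1ccccc1F` gives 1950 nM;
compound 3 `CCCCn1c(=O)n(Cc2ccccc2F)c(=O)c2[nH]c(Cc3ccc(N)cc3N)nc21` gives 5650 nM.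

Among these three, compound 1 has the lowest number in this assay. The nearest measured neighbour is compound 2, and the step of a 5.7-fold higher number from compound 1 to compound 2 (0.76 log units; beyond the scatter) is beyond the scatter, so compound 1 stands as the strongest inhibitor of the three on this read-out; compound 3, which carries a different substituent pattern on its core, lies furthest from it.

The unmeasured compound 4 `Cc1nn(C)cc1S(=O)(=O)Nc1ccc(Cc2nc3c([nH]2)c(=O)n(Cc2ccccc2F)c(=O)n3CC2CC2)cc1` differs from compound 1 in one place: 1,3-dimethyl-1H-pyrazol-4-yl in place of 1,2-dimethyl-1H-imidazol-4-yl on a sulfonyl sulfur. Within the data shown here, the only measured step that touches the same position is that from compound 1 to compound 2, where a pyridinyl group replaced the dimethylimidazolyl and produced a modest weakening. Compound 4 keeps the same atoms as compound 1, joined differently, and the new group, like the old one, is a dimethylated five-membered aromatic ring with two hetero atoms. Among the measured compounds shown here, with no direct precedent for this exact change, a step in this assay within the scatter, or at most a small weakening, is expected, so the estimated step of a 1.5-fold higher number from compound 1 to compound 4 (0.17 log units; within the scatter) is small. Compound 4 is therefore expected to give about 500 nM, in a range from 180 nM to 1500 nM.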

Compound 4, half-maximal inhibitory concentration: 240 nM
Compound 4: the middle estimate sits 2.1-fold (0.32 log units) above what was measured; the range from low to high includes it.
By their numbers in this assay, from the lowest: compounds 4 and 1 (each within the scatter of the next); then compound 2; then compound 3.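

In this assay, rearranging the same atoms from 1,2-dimethyl-1H-imidazol-4-yl to 1,3-dimethyl-1H-pyrazol-4-yl on the sulfonyl sulfur gives a 1.4-fold lower number from compound 1 to compound 4 (0.15 log units; within the scatter), so the two five-membered rings cannot be told apart on this read-out and the position accepts this change of ring. Among these compounds, the earlier compounds set pyridin-3-yl against only one five-membered ring, whereas an 8.1-fold lower number from compound 2 to compound 4 (0.91 log units; beyond the scatter) shows that the gap to pyridin-3-yl is not confined to the dimethylimidazolyl group, since two differently arranged dimethylated rings now stand apart from it. Nothing measured here gives a reason for the match between the two five-membered rings or for their gap to pyridin-3-yl.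

The compounds shown leave open how a phenyl ring or a plain methyl group on the sulfonyl sulfur would compare with these rings, and so whether a five-membered ring is needed there at all. They also leave open what the two methyl groups contribute, a question that an unsubstituted pyrazol-4-yl or an ethyl group in place of either methyl would address.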